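This account rests on a few compounds, and the source may have more. Where it says the series, first, only, none or still open, it means among the compounds named here.

Measured so far:
compound 1, `CCO/N=C/Nc1cc(Cl)c(CC)c(Cl)c1`: 4.8
compound 2, `CCCCc1c(Cl)cc(N/C=N/OCC)cc1Cl`: 5.6
compound 3, `C#CCc1c(Cl)cc(N/C=N/OC)cc1Cl`: 3.3

Of the compounds shown here, three have been measured in a physicochemical assay for lipophilicity, measured as octanol-water partition; a higher number here means a more lipophilic compound, a lower number a more polar compound. Compound 1 gives 4.8 in this assay, and compound 2 gives 5.6. Compound 3 gives 3.3, the lowest of the three numbers; it stands closest to compound 1 and furthest from compound 2, both gaps beyond the scatter.

Compounds 1 and 2 differ in one place: ethyl in place of hydrogen on a saturated chain carbon, two bonds along the chain from an aromatic carbon. This change gave a step of a number 0.80 log units higher from compound 1 to compound 2 (beyond the scatter), a modest rise.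

Compound 4, `C#CCc1c(Cl)cc(N/C=N/OCCC)cc1Cl`, has not yet been measured. It differs from compound 3 in one place: ethyl in place of hydrogen on a saturated chain carbon bound to an oxygen. Among the compounds with values here, this is the same kind of change as the one from compound 1 to compound 2, but not the same: in the earlier pair the ethyl entered on a saturated chain carbon, two bonds along the chain from an aromatic carbon, whereas here it enters on a saturated chain carbon bound to an oxygen. How the core of compound 3 differs from the core of compound 1 is not broken down here.

Given the step of a number 0.80 log units higher from compound 1 to compound 2 (beyond the scatter), compound 4 is expected to rise by about the same amount in this assay, a step of a number 0.90 log units higher from compound 3 to compound 4 (beyond the scatter). The expected value for compound 4 in this assay is 4.2, with a range from 3.7 to 4.7.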

Compound 4, partition coefficient: 4
Estimate against measurement, compound 4: 0.20 log units above; the measured number falls inside the stated range.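

In this assay, ethyl in place of hydrogen on a saturated chain carbon bound to an oxygen, which turns methoxy into propoxy, gave a step of a number 0.70 log units higher from compound 3 to compound 4 (beyond the scatter), while the same replacement on the core of compound 1, on a saturated chain carbon, two bonds along the chain from an aromatic carbon, gave a step of a number 0.80 log units higher from compound 1 to compound 2 (beyond the scatter). These two steps run the same way and both count as modest, so in these two pairs the replacement carried over from one core to another with a similar outcome. Within the data shown here, this does not make a rule: there are only two pairs, the ethyl enters at a different place in each, and nothing available explains why the two steps resemble each other.

The compounds shown leave open whether a similar step would appear on a third core, or with the ethyl at one and the same place on both cores. They also leave open how the number would move if a longer chain such as hexyl, an amine or a carboxylic acid entered in place of that hydrogen.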